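From 1H-imidazol-4-yl to thiophen-3-yl on the shared core

This account rests on a few compounds, and the source may have more. Where it says the series, first, only, none or still open, it means among the compounds named here.

Measured in a functional assay on HCT-116 cells (Homo sapiens), read by sulforhodamine B assay, with a stated time of 5 days; a lower number here means a stronger inhibitor of growth, a higher number a weaker inhibitor of growth:
compound 1 `OC[C@H]1O[C@@H](n2cc(F)c3c(-c4ccco4)ncnc32)[C@H](O)[C@@H]1O`: 39 nM
compound 2 `OC[C@H]1O[C@@H](n2cc(F)c3c(-c4nccs4)ncnc32)[C@H](O)[C@@H]1O`: 1300 nM
compound 3 `OC[C@H]1O[C@@H](n2cc(F)c3c(-c4c[nH]cn4)ncnc32)[C@H](O)[C@@H]1O`: > 10000 nM

Compound 3 has no number, and its > 10000 nM is only a limit of the assay. Compound 4 `OC[C@H]1O[C@@H](n2cc(F)c3c(-c4ccsc4)ncnc32)[C@H](O)[C@@H]1O` carries thiophen-3-yl in place of 1H-imidazol-4-yl on an aromatic carbon. Among the measured compounds shown here, three measured steps bear on this change, all with a change of group at the same place. Replacing furan-2-yl with 1H-imidazol-4-yl gave an at least 250-fold higher number from compound 1 to compound 3 (2.40 log units; beyond the scatter), and replacing 1,3-thiazol-2-yl with it gave an at least 7.6-fold higher number from compound 2 to compound 3 (0.88 log units; beyond the scatter). Replacing furan-2-yl with 1,3-thiazol-2-yl gave a 33-fold higher number from compound 1 to compound 2 (1.52 log units; beyond the scatter). Thiophen-3-yl, like furan-2-yl, has no ring nitrogen, so compound 4 is expected to lie nearer compound 1 at 39 nM than compound 2 at 1300 nM. A large step to a lower number is therefore expected in this assay, and the expected size is an at least 140-fold lower number from compound 3 to compound 4 (2.15 log units; beyond the scatter). Compound 4 is estimated at 70 nM, with an expected range of 15 nM to 400 nM.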

Compound 4, concentration for 50% growth inhibition: 140 nM
The estimate for compound 4 lay 2.0-fold (0.30 log units) below the measured number; the range from low to high includes it.
By their numbers in this assay, from the lowest: compound 1; then compound 4; then compound 2. At a limit, above all of these: compound 3.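

In this assay, thiophen-3-yl in place of 1H-imidazol-4-yl gives an at least 71-fold lower number from compound 3 to compound 4 (1.85 log units; beyond the scatter); compound 3 stands at a limit, so this size is only a bound: the limit of > 10000 nM in this assay, at which 1 of the 4 values shown sits. Thiophen-3-yl in place of 1,3-thiazol-2-yl gives a 9.3-fold lower number from compound 2 to compound 4 (0.97 log units; beyond the scatter), and among these four compounds the two rings with no ring nitrogen, in compound 1 and compound 4, give the lowest numbers, with no compound here going against this. Lacking a ring nitrogen does not by itself match compound 1, however: thiophen-3-yl in place of furan-2-yl gives a 3.6-fold higher number from compound 1 to compound 4 (0.56 log units; beyond the scatter).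

Compound 1 and compound 4 differ in both the ring hetero atom and the ring's point of attachment, and these two changes cannot be separated here. Going by these compounds, how thiophen-2-yl, phenyl or an amine would read at this place stays open.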